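A few compounds are considered here, and "the series" means these few. Any claim that something is new, unique, unknown or untested is made for them only; others in the source may bear on it.

Measured so far:
Compound 1, `O=C1C=C(Nc2ccc(I)cc2)C(=O)c2c1nc1n2[C@H]2OC[C@@H](O)[C@H]2OC1`: 2230 nM
Compound 2, `COc1ccccc1NC1=CC(=O)c2c(nc3n2[C@H]2OC[C@@H](O)[C@H]2OC3)C1=O`: 6580 nM

Both compounds share one core and differ only in the ring attached to the amine nitrogen. In a functional assay on MCF7 cells (Homo sapiens) for inhibition, read by sulforhodamine B assay (on this read-out lower numbers stand for stronger inhibition and higher numbers for weaker inhibition), compound 1 gives 2230 nM, the lower of the two numbers, and so the stronger inhibition shown here. Compound 2 gives 6580 nM in this assay, a gap that lies beyond the usual scatter of repeated measurements, so compound 1 stands clearly ahead of compound 2.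

Compound 3, `O=C1C=C(Nc2ccccc2F)C(=O)c2c1nc1n2[C@H]2OC[C@@H](O)[C@H]2OC1`, has not yet been measured. It departs from compound 1 in one place: 2-fluorophenyl in place of 4-iodophenyl on an amine nitrogen

Going by the values given here, no pair of measured compounds isolates this kind of exchange, so the size of the step can only be guessed. Among the compounds with values here, the only other measured compound also carries a ring without the iodine; because that compound, compound 2, gives 6580 nM, a move toward a higher number seems the more likely outcome. The step from compound 1 to compound 3 in this assay is expected to be a 2.2-fold higher number from compound 1 to compound 3 (0.35 log units; beyond the scatter), of modest size. Compound 3 is therefore estimated at 5000 nM in this assay, within a range from 2000 nM to 12000 nM.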

Compound 3, half-maximal inhibitory concentration: 3640 nM
For compound 3 the middle estimate is 1.4-fold (0.14 log units) above the measured one, and the stated range covers the measured number.
By their numbers in this assay, from the lowest: compounds 1, 3 and 2 (each within the scatter of the next, the first and the last beyond it).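

In this assay, putting 2-fluorophenyl in place of 4-iodophenyl on the amine nitrogen gives a 1.6-fold higher number from compound 1 to compound 3 (0.21 log units; within the scatter), so the exchange cannot be told apart from the ordinary spread of repeated measurements. This is the first step shown in which only this ring changes while the rest of the molecule stays fixed, and it shows that this position can take a quite different halogen-bearing phenyl ring without a shift beyond the scatter. Nothing available here offers an explanation for how closely the two compounds read.

This single step changes both the halogen and its place on the ring, so the part played by each cannot be read separately, and a 4-fluorophenyl or 2-iodophenyl group on the same nitrogen would be the direct way to pull them apart. On these data alone, it also remains open how the read-out would respond to something other than a substituted phenyl ring here, such as a cyclohexyl group or a short chain ending in an amine.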